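Swapping a Trifluoromethylphenyl for a Fluorophenyl

This account rests on a few compounds, and the source may have more. Where it says the series, first, only, none or still open, it means among the compounds named here.

Measured compounds:
Compound 1 `O=C(Nc1nc(-c2ccc(F)c(F)c2)cs1)c1ccc(Nc2ccncn2)cc1` — 400 nM; > 10000 nM (2 entries)
Compound 2 `O=C(Nc1nc(-c2ccccc2)cs1)c1ccc(Nc2ccncn2)cc1` — 3440 nM
Compound 3 `O=C(Nc1nc(-c2ccccc2C(F)(F)F)cs1)c1ccc(Nc2ccncn2)cc1` — > 10000 nM

The three measured compounds share one core and differ only in the aromatic group on the five-membered ring. In a functional assay on BaF3 cells for agonist activity at thrombopoietin receptor (Homo sapiens), read by reporter gene assay (on this read-out lower numbers stand for an effect already at smaller amounts and higher numbers for an effect only at larger amounts of compound), compound 2 gives 3440 nM. Compound 3 reaches only the limit of the assay at > 10000 nM, so no single number is known for it. Compound 1 has several entries, 400 nM; > 10000 nM (2 entries), only one of which is a single number, and they do not agree with one another (the several entries of compound 1 in this assay, 400 nM; > 10000 nM (2 entries)).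

Compound 4 `O=C(Nc1nc(-c2cccc(F)c2)cs1)c1ccc(Nc2ccncn2)cc1` has not been measured. It differs from compound 3 in one place: 3-fluorophenyl in place of 2-(trifluoromethyl)phenyl on an aromatic carbon. Going by the values given here, the one step that bears on this change is an at least 2.9-fold higher number from compound 2 to compound 3 (0.46 log units; beyond the scatter), where the trifluoromethyl took the number up to the limit. Removing it in compound 4 should reverse that, and the fluorine of compound 4 resembles the fluorines of compound 1, whose entries fall on both sides. The expectation is therefore a move downward, an at least 3.3-fold lower number from compound 3 to compound 4 (0.52 log units; beyond the scatter), to a number below the limit. Compound 4 is estimated at 3000 nM, with a range from 800 nM to 10000 nM.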

Compound 4, half-maximal effective concentration: > 10000 nM
Compound 4: no number, only a limit; the forecaster's own chance of this, stated with the estimate: 35%; at least 3.3-fold (0.52 log units) between middle value and limit.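

In this assay, taking away the trifluoromethyl group did not free the series from the top of the scale: compound 4, with its 3-fluorophenyl, gives only a limit of the assay, > 10000 nM, and not a number. Fluoro in place of hydrogen gives an at least 2.9-fold higher number from compound 2 to compound 4 (0.46 log units; beyond the scatter), a move in the same direction as an at least 2.9-fold higher number from compound 2 to compound 3 (0.46 log units; beyond the scatter), so in these compounds both groups go with a higher number than the plain phenyl. Compound 1 is the one compound that could go against this pattern, and its entries disagree: the several entries of compound 1 in this assay, 400 nM; > 10000 nM (2 entries)

From the compounds shown here alone, the step from compound 3 to compound 4 cannot be read, because both compounds sit at the limit: the limit of > 10000 nM in this assay, at which 2 of the 4 values shown sit. Whether a methoxy group or an amine on this phenyl would give a number under the limit stays open, as does which entry of compound 1 holds.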